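The compounds below may be only part of what the source reports. "The series", "measured", "known", "first", "only" and "open" are said of these compounds alone.

Compound 2 `CCCCc1cn([C@H]2C[C@H](O)[C@@H](CO)O2)c(=O)[nH]c1=O` carries a butyl chain on the shared core. In a functional assay on Raji cells (Homo sapiens) (a higher number here means a weaker inhibitor, a lower number a stronger inhibitor), compound 2 gives > 500 ug/mL, which is a limit of the assay rather than a number. Compound 1 `CCCCCCc1cn([C@H]2C[C@H](O)[C@@H](CO)O2)c(=O)[nH]c1=O` carries a hexyl chain instead, and in this assay compound 1 gives 151 ug/mL. Among the compounds with values here, the only measured step, an at least 3.3-fold higher number from compound 1 to compound 2 (0.51 log units; beyond the scatter), shows the shorter chain as the weaker inhibitor, though the limit of > 500 ug/mL in this assay, at which 1 of the 2 values shown sits, leaves its full size open. Compound 3 `CCCCCc1cn([C@H]2C[C@H](O)[C@@H](CO)O2)c(=O)[nH]c1=O` differs from compound 2 by methyl in place of hydrogen on a saturated chain carbon, four bonds along the chain from an aromatic carbon. This restores part of the chain whose removal gave the step of an at least 3.3-fold higher number from compound 1 to compound 2 (0.51 log units; beyond the scatter), so for compound 3 a fall in the number is expected, about an at least 1.6-fold lower number from compound 2 to compound 3 (0.22 log units; that floor lies within the scatter). Compound 3 is thus estimated at 300 ug/mL, likely between 150 ug/mL and 600 ug/mL.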

Compound 3, concentration for 50% inhibition: 334 ug/mL
Compound 3: the middle estimate sits 1.1-fold (0.05 log units) below what was measured, within the range that was stated.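

In this assay, removing just the end carbon of the hexyl chain already weakens inhibition, with a 2.2-fold higher number from compound 1 to compound 3 (0.34 log units; beyond the scatter). Adding a methyl to the butyl chain gives an at least 1.4-fold lower number from compound 2 to compound 3 (0.17 log units; that floor lies within the scatter), which on its own does not establish a change. Compound 2 is a limit of the assay, so the true size of that step stays open: the limit of > 500 ug/mL in this assay, at which 1 of the 3 values shown sits.

The compounds shown leave open whether inhibition keeps strengthening with a longer chain such as octyl. They also leave open what a polar chain end, such as an amine or a carboxylic acid, would do.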